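Lengthening the Chain: From Compound 2 to Compound 4

The compounds below may be only part of what the source reports. "The series", "measured", "known", "first", "only" and "open" are said of these compounds alone.

Of the compounds shown here, three have so far been measured in a functional assay on cells (Lymphocyte, Homo sapiens) for inhibition, read by flow cytometry, using a membrane potential dye, with a stated time of 16 h, tested at 250 nM; on this read-out lower numbers stand for a weaker effect and higher numbers for a stronger effect at the one concentration tested. Compound 1 `CCCCCCCCCCCCCCCCc1c(C)c(N(C)C)nc(C)c1O` gives 83%. Compound 2 `CCCCCCCCCCc1c(C)c(N(C)C)nc(C)c1O` gives 78%. Compound 3 `CCCCCCCCCCc1nc(N(C)C)c(C)c(C)c1O` gives 82%. Compound 2 holds the lowest of the three numbers, yet its gaps to compound 3 and to compound 1 both lie within the usual scatter, so no order among the three can be read from these numbers.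

The unmeasured compound 4 `CCCCCCCCCCCCCCCCCCCc1c(C)c(N(C)C)nc(C)c1O` differs from compound 2 in one place: nonyl in place of hydrogen on a saturated chain carbon, ten or more bonds along the chain from an aromatic carbon. Within the data shown here, one measured step bears on this kind of change, the removal of a stretch of chain at the same sort of place: a number 5 percentage points lower from compound 1 to compound 2 (within the scatter), a difference that stays within the scatter. Among the measured compounds shown here, the change to compound 4 runs in the other direction, adding to the chain rather than taking from it, and by a somewhat longer stretch, but nothing among the measured numbers suggests that chain length at this distance from the ring moves the read-out beyond the scatter. The step expected in this assay is a number 3 percentage points higher from compound 2 to compound 4 (within the scatter), essentially none beyond the scatter. Compound 4 is therefore estimated at 81%, with a range from 70% to 91%.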

Compound 4, a percentage reported as activity, at one concentration (the size of the read-out at that concentration, not a potency): 42%
The estimate for compound 4 lay 39 percentage points above the measured number; the measured number lies below the stated range.
By their numbers in this assay, from the lowest: compound 4; then compounds 2, 3 and 1 (each within the scatter of the next).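

In this assay, the chain at this place proves able to move the read-out well beyond the scatter: nonyl in place of hydrogen gives a number 36 percentage points lower from compound 2 to compound 4 (beyond the scatter), and the smaller addition of propyl in place of hydrogen gives a number 41 percentage points lower from compound 1 to compound 4 (beyond the scatter). The earlier step, a number 5 percentage points lower from compound 1 to compound 2 (within the scatter), stayed within the scatter, so among these three compounds on the shared core the read-out holds steady up to the chain of compound 1 and falls only with the further lengthening to the chain of compound 4. No measurement shown here accounts for this fall.

The compounds leave open where between the chains of compound 1 and compound 4 the fall sets in, and whether a still longer chain would lower the number further. They also leave open whether a chain ending in an amine or a carboxylic acid at this place would behave like the plain chain of compound 4, and whether the same lengthening would have a similar effect on the core of compound 3.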